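Notes on a lactone series: from compound 2 to compound 3

This account rests on a few compounds, and the source may have more. Where it says the series, first, only, none or still open, it means among the compounds named here.

Compound 1 `O=C1OC(Cc2nc(-c3ccc(-c4ccccc4)cc3)no2)c2ccccc21` and compound 2 `CCC(C)Oc1ccc(C(O)C2OC(=O)c3c(OC)cc(OC)cc32)cc1` were both run in a functional assay on RAW264.7 cells (Mus musculus) for inhibition, read by Griess assay, with stated times of 1 h and 24 h; on this read-out lower numbers stand for stronger inhibition and higher numbers for weaker inhibition. For compound 1 the assay reports only a limit, > 10000 nM. For compound 2 the assay likewise reports only a limit, > 10000 nM. Among the compounds with values here, compound 2 therefore stands at the limit of > 10000 nM in this assay, at which 2 of the 2 values shown sit, and no measured step between the two compounds can be set out. Compound 3 `COc1cc(OC)c2c(c1)C(C(O)c1ccc(OCc3ccc(Br)cc3)cc1)OC2=O` differs from compound 2 by 4-bromobenzyl in place of sec-butyl on an oxygen on an aromatic ring. With nothing measured to build on, the expected step is a step that the limit leaves unreadable from compound 2 to compound 3, not beyond the scatter. Compound 3 is accordingly estimated at 15000 nM in this assay, with a range from 3000 nM to 80000 nM.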

Compound 3, half-maximal inhibitory concentration: 6530 nM
The estimate for compound 3 lay 2.3-fold (0.36 log units) above the measured number, and the stated range covers the measured number.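

In this assay, 4-bromobenzyl in place of sec-butyl on an oxygen on an aromatic ring gives an at least 1.5-fold lower number from compound 2 to compound 3 (0.18 log units; that floor lies within the scatter). Within the data shown here, this is the first sign that this oxygen can carry a change that yields a number rather than a limit, though the step read so far does not clear the scatter. Compound 3 alone among the compounds shown has a measured number: the limit of > 10000 nM in this assay, at which 2 of the 3 values shown sit.

From the compounds shown here alone, the full size of the step stays open, as compound 2 has only a limit. Also open, going by these compounds, is whether the bromine matters, which a plain benzyl on the same oxygen would test.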